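The source may report more compounds than this note shows. Statements on the series, on what has been measured and on what is new or still open speak of the compounds shown alone.

Of the compounds shown here, two of this set have been tested in a functional assay (Homo sapiens) for inhibition of Nucleic Acid, tested at 100 uM; a higher number here means more inhibition at the concentration tested (going by the name of the read-out), a lower number less inhibition. Compound 1, with the structure `CCCCCCNc1[nH]ccc2ncnc1-2`, carries a hexyl chain on the nitrogen attached to its core; in this assay compound 1 gives 53%. Compound 2, built on a different core with a sugar-like ring and the structure `[N-]=[N+]=Nc1nccc2ncn([C@H]3C[C@H](O)[C@@H](CO)O3)c12`, gives 14% in this assay. Of the two numbers, compound 1 stands highest, and the gap to compound 2 is wider than the usual scatter of repeated measurements, so the two values can be told apart.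

The step of interest leads from compound 1 to compound 3, whose structure is `OCCNc1[nH]ccc2ncnc1-2`. The change is hydroxy in place of butyl on a saturated chain carbon, two bonds along the chain from a nitrogen on an aromatic ring. Among the compounds with values here, no pair of measured compounds shows this kind of change, so there is no measured step to lean on. A moderate fall in inhibition, beyond the scatter, is expected, with the step from compound 1 to compound 3 estimated as a number 23 percentage points lower from compound 1 to compound 3 (beyond the scatter). For compound 3 the value in this assay is estimated at 30%, most likely between 10% and 52%.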

Compound 3, a percentage reported as inhibition, at one concentration (the size of the read-out at that concentration, not a potency): 3%
Compound 3: the middle estimate sits 27 percentage points above what was measured, outside the stated range (below it).
By their numbers in this assay, from the lowest: compound 3; then compound 2; then compound 1.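

The side chain of the core of compound 1 turns out not to be a place where changes pass without effect: hydroxy in place of butyl on a saturated chain carbon, two bonds along the chain from a nitrogen on an aromatic ring, gives a number 50 percentage points lower from compound 1 to compound 3 (beyond the scatter) in this assay. With the butyl gone and the hydroxy in its place, compound 3 reads 3%, so this single change on an otherwise unchanged core takes away nearly all the inhibition that compound 1 shows at the concentration tested. Nothing in the available data explains why the number falls so far, and the step records only the size of the effect.

This one step swaps two things at once, removing a four-carbon butyl and bringing in a hydroxy with its hydrogen-bond donor and acceptor, so the loss of the chain and the arrival of the hydroxy cannot be told apart. Open too, going by these compounds, is how a plain methyl at this carbon would read, or an amine, a carboxylic acid or a chain longer than the hexyl of compound 1.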